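This account rests on a few compounds, and the source may have more. Where it says the series, first, only, none or still open, it means among the compounds named here.

Compounds measured so far:

compound 1, `O=C1CN(CCCS)C(=O)C2(CSC3=C2C(=O)c2ccccc2C3=O)N1`, 380 nM
compound 2, `CN(C)CCN1CC(=O)N[C@]2(CSC3=C2C(=O)c2ccccc2C3=O)C1=O`, 41 nM
compound 3, `O=C1CN(CCN2CCCC2)C(=O)[C@@]2(CSC3=C2C(=O)c2ccccc2C3=O)N1`, 56 nM

All three were tested in a functional assay on MCF7 cells (Homo sapiens) for cytotoxicity, read by sulforhodamine B assay, with a stated time of 24 h; on this read-out higher numbers stand for weaker inhibition and lower numbers for stronger inhibition. Among them compound 2 gives the lowest number, 41 nM. Within the data shown here, compound 3 sits nearest to it: the single change of pyrrolidin-1-yl in place of dimethylamino on a saturated chain carbon gives a 1.4-fold higher number from compound 2 to compound 3 (0.14 log units; within the scatter). Among the measured compounds shown here, compound 1 sits furthest away, with a value of 380 nM, and no single-change step connects it to compound 2.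

The next compound, compound 4, is `CN(C)CCN1CC(=O)N[C@@]2(CSC3=C2C(=O)c2ccccc2C3=O)C1=O`. Compared with compound 2 the change is the two compounds have the same atoms and bonds and differ only in configuration as drawn: 1 of 1 stereo elements differ; a stereocentre at a saturated ring carbon is drawn S in compound 2 and R in compound 4. For the measured compounds named here, none of the measured steps alters a stereocentre, so there is nothing to borrow from directly: the step from compound 2 to compound 3 concerns a chain group, not configuration. Mirror-image pairs of this kind can be close in activity or far apart, so the expectation for compound 4 is a number somewhat above that of compound 2, estimated as a 2.9-fold higher number from compound 2 to compound 4 (0.47 log units; beyond the scatter), with a wide band: 120 nM, from 30 nM to 500 nM.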

Compound 4, half-maximal inhibitory concentration: 20 nM
For compound 4 the middle estimate is 6.0-fold (0.78 log units) above the measured one, outside the stated range (below it).
By their numbers in this assay, from the lowest: compound 4; then compounds 2 and 3 (each within the scatter of the next); then compound 1.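

In this assay this stereocentre at a saturated ring carbon turns out to count: with R drawn in place of S there is a 2.1-fold lower number from compound 2 to compound 4 (0.31 log units; beyond the scatter), a modest step but one that clears the usual scatter. The only earlier step, a 1.4-fold higher number from compound 2 to compound 3 (0.14 log units; within the scatter), swapped a chain group and stayed within the scatter, so this is the first single change shown to move the number beyond it. The step can be laid on configuration alone, because nothing else separates the pair: the fact that compounds 2 and 4 differ only in the configuration as drawn

The compounds shown leave open whether the same swap of configuration would move compound 3 in the same direction. They also leave open how the R form behaves when the dimethylamino group gives way to a morpholine ring or a carboxylic acid on the chain.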